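The compounds below may be only part of what the source reports. "The series", "measured", "known", "first", "only" and "open" are said of these compounds alone.

Measured in an ADME assay (Rattus norvegicus, strain Wistar Han) for metabolic stability; a lower number here means that the compound disappears faster, a higher number that the compound lasts longer:
- compound 1 `CCC(=O)N1CC[C@H](Nc2ncnc3c2nc(-c2cnn(CC)c2C)n3C)C1`: 0.4 h
- compound 2 `CCn1ncc(-c2nc3c(N[C@H]4CCN(C(=O)C5CC5)C4)ncnc3n2C)c1C`: 0.3 h

Only these two compounds have been measured, and their values lie within the usual scatter of each other. On these numbers, compound 2 therefore cannot be said to last longer or shorter than compound 1. Within the data shown here, the single measured step, a 1.3-fold lower number from compound 1 to compound 2 (0.12 log units; within the scatter), replaced ethyl with cyclopropyl on a carbonyl carbon.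

Compound 3 `CCn1ncc(-c2nc3c(N[C@H]4CCN(C(=O)C5CCOCC5)C4)ncnc3n2C)c1C` keeps the rest of compound 2 but has oxan-4-yl in place of cyclopropyl on a carbonyl carbon whose other neighbour is an amide-type nitrogen in a ring: oxan-4-yl in place of cyclopropyl on a carbonyl carbon.

The measured step changed the same place and stayed within the scatter, so it offers no sign of a trend. Among the measured compounds shown here, it is only a weak guide, however, since no measured compound carries oxan-4-yl. No shift beyond the scatter in this assay is expected, in either direction. The expected step is a 1.3-fold higher number from compound 2 to compound 3 (0.12 log units; within the scatter). For compound 3 the estimated half-life is 0.4 h, with an expected range from 0.2 h to 0.9 h.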

Compound 3, half-life: 0.2 h
Beside the measured number, compound 3's estimate is 2.0-fold (0.30 log units) above it; low and high end bracket the measured number.
By their numbers in this assay, from the lowest: compounds 3, 2 and 1 (each within the scatter of the next).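

At the carbonyl carbon whose other neighbour is an amide-type nitrogen in a ring, oxan-4-yl brings 6 heavy atoms, one of them oxygen, and 1 hydrogen-bond acceptor in place of the 3 carbon atoms of cyclopropyl, and this assay shows a 1.5-fold lower number from compound 2 to compound 3 (0.18 log units; within the scatter) for this exchange. Set against ethyl at the same place, oxan-4-yl gives a 2.0-fold lower number from compound 1 to compound 3 (0.30 log units; within the scatter) and so adds a six-membered ring with a hetero atom to the groups that remain within the scatter of one another, which means this larger change reveals no trend in half-life any more than the earlier step did. No measurement at hand bears on what lies behind these numbers.

Still open, on these data alone, is whether a different kind of group on this carbonyl carbon, such as an amine, a carboxylic acid or a longer chain, would move the half-life beyond the scatter. As far as these compounds go, all three compounds also share the same core and the same ethyl-bearing end, so what a change elsewhere in the molecule would do to this assay remains unknown.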